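Adding a hydroxy group to compound 2

The source may hold more compounds than are shown below. What is called first, only, known or untested is meant among the compounds shown, and "the series" means these compounds.

Measured so far in an ADME assay for metabolic stability, at pH 1.5; on this read-out lower numbers stand for a shorter-lived compound and higher numbers for a longer-lived compound:
- Compound 1 `Nc1ncnc2c1ncn2[C@H]1C=C[C@@H](CO)O1`: < 0.01 h, a limit of the assay and not a number
- Compound 2 `Cc1cccc2c1OP(=O)(OCC1CCC(n3cnc4c(O)ncnc43)O1)OC2`: 0.2 h

Not yet measured:
- Compound 3 `Cc1cccc2c1OP(=O)(OCC1CC(O)C(n3cnc4c(O)ncnc43)O1)OC2`

For the measured compounds named here, only two compounds have been tested, and no measured pair differs in just one place. Going by the values given here, compound 2 gives 0.2 h, the only true number in this small set. Compound 1 sits at a limit, so it gives no exact half-life to compare.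

Compound 3 is compound 2 with one change: hydroxy in place of hydrogen on a saturated ring carbon. This places hydroxy in place of hydrogen on a saturated ring carbon, and nothing else in the structure differs.

Among the compounds with values here, with no measured step as a guide, the expectation is a judgement from the structural change alone. Compound 2, at 0.2 h, leaves plenty of room for a longer half-life. In this assay, a clear rise beyond the usual scatter is expected, and the estimated change is a 50-fold higher number from compound 2 to compound 3 (1.70 log units; beyond the scatter). Compound 3 is expected to show a half-life of about 10 h, within an estimated range of 1.5 h to 60 h.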

Compound 3, half-life in the ADME assay: < 0.1 h
Compound 3 ended at the assay's limit; the forecaster's own chance of this, stated with the estimate: 15%; at least 100-fold (2.00 log units) between middle value and limit.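

For the compounds shown here, this pair gives the first comparison in the set between two compounds that differ in one place. In the ADME assay compound 2 gives 0.2 h. In the ADME assay compound 3 gives < 0.1 h, a limit of the assay and not a number. In the ADME assay, hydroxy in place of hydrogen on a saturated ring carbon, next to the ring atom that bears a large group, gives an at least 2.0-fold lower number from compound 2 to compound 3 (0.30 log units; that floor lies within the scatter), so this change at this position brings no sign of a longer half-life. On these data alone, the true size of the step stays unknown, because compound 3 is reported as a limit of the assay and not as a number: the limit of < 0.1 h in the ADME assay, at which 1 of the 3 values shown sits. In a physicochemical assay for lipophilicity (on this read-out lower numbers stand for lower lipophilicity and higher numbers for higher lipophilicity), compound 2 gives 0.14 and compound 3 gives 0.078. In the physicochemical assay the same change gives a number 0.06 log units lower from compound 2 to compound 3 (within the scatter), so the two compounds cannot be told apart on that read-out.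

Whether the half-life of compound 3 lies just under its limit or far under it stays open, and so does the reason for this result. Also open, as far as these compounds go, is how the ADME assay would respond to a different group on the same saturated ring carbon, such as an amine, a fluorine atom or a methoxy group, since a single hydroxy example cannot show whether the outcome is specific to hydroxy or holds for substitution at this position in general.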